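A few compounds are considered here, and "the series" means these few. Any claim that something is new, unique, unknown or untested is made for them only; others in the source may bear on it.

Series notes. Compound 1 `COc1cc(/C=C/C(=O)NC2CCN(Cc3ccccc3)CC2)ccc1O` and compound 2 `COc1cc(/C=C/C(=O)NC2CCN(Cc3ccccc3)CC2)cc(OC)c1O` share one core and differ by hydrogen in place of methoxy on an aromatic carbon. In a physicochemical assay, read by spectrophotometry, with a stated time of 30 min (a lower number here means a stronger inhibitor, a higher number a weaker inhibitor), compound 1 gives 32500 nM, and compound 2 gives 22300 nM; the step is a 1.5-fold higher number from compound 2 to compound 1 (0.16 log units; within the scatter). Compound 3 `COc1cc(/C=C/C(=O)CC(=O)NC2CCN(Cc3ccccc3)CC2)ccc1O` carries a different core, and how the core of compound 3 differs from that of compound 2 is not broken down here. In this assay compound 3 gives 88700 nM, the highest number of the three measured, its gaps to compound 1 and compound 2 both beyond the scatter.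

Compound 4 `O=C(/C=C/c1ccc(O)cc1)CC(=O)NC1CCN(Cc2ccccc2)CC1` is not yet measured; it differs from compound 3 by hydrogen in place of methoxy on an aromatic carbon. This is the same kind of change as that from compound 2 to compound 1, not the same: in compound 2 the place is also meta to a methoxy group, whereas in compound 3 it is not. For compound 4 the expected step from its parent is a 1.5-fold higher number from compound 3 to compound 4 (0.17 log units; within the scatter), a small one, because a 1.5-fold higher number from compound 2 to compound 1 (0.16 log units; within the scatter) stayed within the scatter. Compound 4 is thus estimated at about 130000 nM, with a likely range from 60000 nM to 300000 nM.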

Compound 4, half-maximal inhibitory concentration: 890000 nM
For compound 4 the middle estimate is 6.8-fold (0.84 log units) below the measured one; the whole stated range lies below it.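

In this assay the same replacement of methoxy by hydrogen gives a 10-fold higher number from compound 3 to compound 4 (1.00 log units; beyond the scatter) and lies beyond the scatter, whereas on the other core it gives a 1.5-fold higher number from compound 2 to compound 1 (0.16 log units; within the scatter) and stays within the scatter. The small step seen on the core of compound 2 therefore did not carry over to the core of compound 3, so in this series the size of this change depends on the core it sits on. With only two pairs, this shows that the two cores differ in their response but not which part of the core matters or how general this is, and nothing shown here bears on the reason for the gap.

On these data alone, it remains open whether the large step on the core of compound 3 belongs to the loss of methoxy in particular or would also appear with ethoxy, chlorine or an amine at that place. As far as these compounds go, it is also open how 4-hydroxyphenyl would compare with 4-hydroxy-3-methoxyphenyl on further cores, which would show whether either of the two steps is the more typical.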